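Ester to Acid on a Pyrrolidinone Scaffold

The source may report more compounds than this note shows. Statements on the series, on what has been measured and on what is new or still open speak of the compounds shown alone.

Measured compounds:
- compound 1, `O=C(O)c1ccc(COc2ccc(CN3C(=O)CC[C@H]3C(=O)NCc3ccccc3)cc2)cc1`, > 5000 nM in an assay on HEK293 cells for inhibition of Ataxin-2 (Mus musculus), read by fluorescence and Amplex Red; a lower number here means a stronger inhibitor, a higher number a weaker inhibitor
- compound 2, `COC(=O)c1ccc(COc2ccc(CN3C(=O)CC[C@H]3Cn3ccnc3)cc2)cc1`, > 5000 nM in this assay

Compound 2 gives > 5000 nM in this assay, and that figure is a limit of the assay rather than a number. Compound 1 likewise gives > 5000 nM, again a limit. Both values therefore sit at the same boundary, as summarised in the limit of > 5000 nM in this assay, at which 2 of the 2 values shown sit, so neither compound shows measurable inhibition here.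

Compound 3, `O=C(O)c1ccc(COc2ccc(CN3C(=O)CC[C@H]3Cn3ccnc3)cc2)cc1`, has not yet been measured. It differs from compound 2 by hydrogen in place of methyl on an oxygen next to a carbonyl group. For the measured compounds named here, no step between measured compounds exists to show what this change does; compound 1 already carries the acid, yet its different other end makes it no direct comparison.

The step from compound 2 to compound 3 is expected to be a step that the limit leaves unreadable from compound 2 to compound 3, meaning no change beyond the scatter. Compound 3 is estimated at 8000 nM, most likely again reported as a limit, within 3000 nM to 30000 nM.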

Compound 3, half-maximal inhibitory concentration: > 5000 nM
Compound 3 ended at the assay's limit (the forecaster's own chance of this, stated with the estimate: 80%); the middle value does not contradict the limit.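

Compound 3 also ends at a limit of this assay, so the changes leading to it from compound 2 and from compound 1 cannot be read: the limit of > 5000 nM in this assay, at which 3 of the 3 values shown sit. The compounds shown leave open how large either change really is, since none gives a true number.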